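This account rests on a few compounds, and the source may have more. Where it says the series, first, only, none or still open, it means among the compounds named here.

Measured in a functional assay on MT4 cells (Homo sapiens) for cytotoxicity; a higher number here means that more compound is tolerated, a lower number that less compound is tolerated:
- compound 1 `CC(=O)CSc1nc(O)c(C)c(Cc2cccc3ccccc23)n1`: 85000 nM
- compound 2 `CCc1c(O)nc(SCC(=O)c2ccc(OC)cc2)nc1Cc1cccc2ccccc12`: 178000 nM
- compound 3 `CC(=O)CSc1nc(O)c(C(C)C)c(Cc2cccc3ccccc23)n1`: 43000 nM

Compound 3, at 43000 nM, cannot be separated from compound 1 on these numbers: the measured step is a 2.0-fold lower number from compound 1 to compound 3 (0.30 log units; within the scatter). Compound 2, at 178000 nM, stands clearly higher than compound 3.

The next compound is compound 4 `CCOC(=O)CSc1nc(O)c(C(C)C)c(Cc2cccc3ccccc23)n1`, with ethoxy in place of methyl on a carbonyl carbon, which reads as acetyl to ethoxycarbonyl (ethoxy in place of methyl on a carbonyl carbon). For the measured compounds named here, the one measured step is an isopropyl for methyl swap on an aromatic carbon, at a different place, so it bears on this change only indirectly. It does show that one exchange on the shared core left the number within the scatter. Going by the values given here, no measured step isolates a change on the carbonyl carbon. Compound 2 has another group there but also differs elsewhere, so its value widens the range upward and gives no step size.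

The expectation is therefore no step beyond the scatter, with a wide margin. The estimated change is a 1.2-fold higher number from compound 3 to compound 4 (0.07 log units; within the scatter). For compound 4 the expected value in this assay is 50000 nM, with an estimated range of 20000 nM to 120000 nM.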

Compound 4, half-maximal cytotoxic concentration: 175000 nM
Beside the measured number, compound 4's estimate is 3.5-fold (0.54 log units) below it, and the stated range ends below it.
By their numbers in this assay, from the lowest: compounds 3 and 1 (each within the scatter of the next); then compounds 4 and 2 (each within the scatter of the next).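

In this assay, acetyl to ethoxycarbonyl gives a 4.1-fold higher number from compound 3 to compound 4 (0.61 log units; beyond the scatter), the only step shown that isolates a change on this carbonyl carbon. This step is printed as beyond the scatter, whereas a 2.0-fold lower number from compound 1 to compound 3 (0.30 log units; within the scatter), the exchange on the aromatic carbon, lies within it, so among the single-place exchanges shown, only the one on the carbonyl carbon separates two compounds in this assay. The evidence available offers no explanation for the direction or size of this step.

As far as these compounds go, it remains open whether the higher number is specific to ethoxy or would also follow from other groups on the same carbonyl carbon, such as a carboxylic acid, a primary amide or a longer chain such as butoxy. From the compounds shown here alone, it is equally open whether the exchange of methyl for ethoxy on the carbonyl carbon would give a step of similar size with methyl instead of isopropyl on the aromatic carbon.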